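The source may report more compounds than this note shows. Statements on the series, on what has been measured and on what is new or still open speak of the compounds shown alone.

Within the data shown here, compound 2 `COc1ccc(Cl)cc1S(=O)(=O)Nc1cncc(-c2ccncc2)c1` is one of two compounds measured so far in an assay on isolated protein for inhibition of alkaline phosphatase, tissue-nonspecific isozyme (Homo sapiens); on this read-out higher numbers stand for weaker inhibition and lower numbers for stronger inhibition. For compound 2 the read-out is a limit of the assay, > 20000 nM. Compound 1 `COc1ccc(OC)c(S(=O)(=O)Nc2cncc(-c3ccncc3)c2)c1` likewise gives only a limit of the assay in this assay, namely > 20000 nM. The step that the two limits leave unreadable from compound 1 to compound 2 cannot be sized because the limit of > 20000 nM in this assay, at which 2 of the 2 values shown sit, is where both values sit. Compound 3 `COC(=O)c1cncc(NS(=O)(=O)c2cc(Cl)ccc2OC)c1` differs from compound 2 by methoxycarbonyl in place of pyridin-4-yl on an aromatic carbon. Among the measured compounds shown here, no measured step exchanges these two groups, so the two limits are the only guide to what this change might do in this assay. Compound 3 is therefore expected to land near the limit as well, with the step that the limit leaves unreadable from compound 2 to compound 3 carrying little weight. The estimate for compound 3 is 30000 nM, with a range from 8000 nM to 100000 nM, and the likeliest outcome is that only a limit is reported again.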

Compound 3, half-maximal inhibitory concentration: > 20000 nM
Compound 3: no number, only a limit; the forecaster's own chance of this, stated with the estimate: 70%; the middle value is on the limit's open side.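

In this assay compound 3, like compound 2, gives only a limit of the assay, and no new step can be read between them: the limit of > 20000 nM in this assay, at which 3 of the 3 values shown sit. The compounds shown leave open how strongly any of them inhibits and whether methoxycarbonyl in place of pyridin-4-yl changes anything.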